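Compound 3 to compound 4: notes on the series

A few compounds are considered here, and "the series" means these few. Any claim that something is new, unique, unknown or untested is made for them only; others in the source may bear on it.

All results so far come from an ADME assay on HEK293 cells (Homo sapiens) for cytotoxicity, with a stated time of 72 h (on this read-out lower numbers stand for an effect already at smaller amounts and higher numbers for an effect only at larger amounts of compound), and each one is a limit. Compound 1 (`C=C[C@@](C)(/C=C/c1ccc(O)c(/C=C/C#N)c1)CCC=C(C)C`) gives > 36600 nM as a limit and not a number. Compound 2 (`C=C[C@@](C)(/C=C/c1ccc(O)c(/C=C/C(=O)OCc2ccccc2)c1)CCC=C(C)C`) gives > 36600 nM as a limit as well. Compound 3 (`C=C[C@@](C)(/C=C/c1ccc(O)c(/C=C/c2ccc(F)cc2)c1)CCC=C(C)C`) gives > 36600 nM as a limit too, so it has no number of its own. The picture for the series is simply the limit of > 36600 nM in this assay, at which 3 of the 3 values shown sit, and compound 3 sits there with the others.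

The change to compound 4 (`C=C[C@@](C)(/C=C/c1ccc(O)c(/C=C/C=C/c2ccccc2)c1)CCC=C(C)C`) is 2-phenylethenyl in place of 4-fluorophenyl on a double-bonded chain carbon bound to a double-bonded chain carbon and it adds one double bond outside aromatic rings. The group enters on a double-bonded chain carbon bound to a double-bonded chain carbon.

Three measured steps at this same place bear on it: a step that the two limits leave unreadable from compound 2 to compound 3 and a step that the two limits leave unreadable from compound 1 to compound 3 and a step that the two limits leave unreadable from compound 1 to compound 2 and none of them gives a size. None of these exchanges produced a number in this assay so no direction can be read and no step beyond the scatter is expected. The expected outcome is a step that the limit leaves unreadable from compound 3 to compound 4 and a further limit is the likeliest report. For compound 4 the estimate is 40000 nM with an expected range of 18000 nM to 80000 nM in this assay.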

Compound 4, half-maximal effective concentration: > 36600 nM
Compound 4 gave a limit, no number (the forecaster's own chance of this, stated with the estimate: 80%); the middle value lies beyond the limit too.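

Compound 4 also gives a limit and not a number, so its steps from compound 1, compound 2 and compound 3 cannot be read. All four compounds therefore share one reported result: the limit of > 36600 nM in this assay, at which 4 of the 4 values shown sit. The compounds shown leave open how the four rank and whether any exchange at this place changes the read-out.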